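Methoxy for chloro on the chlorophenyl arm of compound 1

This account rests on a few compounds, and the source may have more. Where it says the series, first, only, none or still open, it means among the compounds named here.

Compound 1 `FC(F)(F)c1ccc(C2CC(c3ccc(Cl)cc3)=NN2c2ccc(-c3ccccc3)nn2)cc1` gives 1670 nM in a functional assay on MCF7 cells (Homo sapiens) for antiproliferative activity, read by MTT assay, with a stated time of 24 h (on this read-out higher numbers stand for weaker inhibition and lower numbers for stronger inhibition), the lowest number among the three measured compounds. Compound 2 `COc1ccc(C2CC(c3ccc(Cl)cc3)=NN2c2ccc(-c3ccccc3)nn2)cc1` gives 100000 nM and compound 3 `COc1cc(C2CC(c3ccc(Cl)cc3)=NN2c2ccc(-c3ccccc3)nn2)cc(OC)c1OC` gives 100000 nM; the steps were a 60-fold higher number from compound 1 to compound 2 (1.78 log units; beyond the scatter) and a 60-fold higher number from compound 1 to compound 3 (1.78 log units; beyond the scatter), while no change at the digits printed from compound 2 to compound 3 (within the scatter). Compound 4 `COc1ccc(C2=NN(c3ccc(-c4ccccc4)nn3)C(c3ccc(C(F)(F)F)cc3)C2)cc1` differs from compound 1 by methoxy in place of chloro on an aromatic carbon. Within the data shown here, no measured step alters this aryl group; the two large steps above changed the aryl on the saturated ring carbon, so they bear only indirectly. Among the measured compounds shown here, since the one methoxy entering in compound 2 went with a 60-fold higher number from compound 1 to compound 2 (1.78 log units; beyond the scatter), a moderate rise in this assay is expected for compound 4, namely a 3.6-fold higher number from compound 1 to compound 4 (0.56 log units; beyond the scatter), giving an estimate of 6000 nM with a range from 1500 nM to 40000 nM.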

Compound 4, half-maximal inhibitory concentration: 46800 nM
The estimate for compound 4 lay 7.8-fold (0.89 log units) below the measured number; the measured number lies above the stated range.
By their numbers in this assay, from the lowest: compound 1; then compound 4; then compounds 2 and 3 (each within the scatter of the next).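

Among these compounds, the 4-chlorophenyl arm, which no earlier step touched, turns out to matter: in this assay, 4-methoxyphenyl in its place gives a 28-fold higher number from compound 1 to compound 4 (1.45 log units; beyond the scatter). Keeping the 4-(trifluoromethyl)phenyl group on the saturated ring carbon therefore does not by itself hold the number low. No measurement here explains why this swap raises the number.

One swap at this position cannot show whether chloro is specifically favoured or methoxy is specifically harmful. A fluoro or an amine on the same carbon would help separate those two readings.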